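The source may report more compounds than this note shows. Statements on the series, on what has been measured and on what is new or still open speak of the compounds shown alone.

Compound 3 `COc1ccc2nc(C)cc(OCC(=O)Nc3cc(F)cc(F)c3)c2c1` stands lowest of the three measured numbers in a physicochemical assay for solubility, in phosphate buffer, measured as kinetic solubility, with a stated time of 1 h, at pH 7.4 (on this read-out lower numbers stand for lower solubility and higher numbers for higher solubility), at 13000 nM. Compound 1 `COc1ccc2nc(C)cc(OCC(=O)NCc3cc(C)cc(C)c3)c2c1` gives 92000 nM, and compound 2 `COc1ccc2nc(C)cc(OCC(=O)Nc3cc(C)ccc3C)c2c1` gives 45500 nM. The unmeasured compound 4 `COc1ccc2nc(C)cc(OCC(=O)Nc3ccc(Cl)cc3)c2c1` differs from compound 3 by 4-chlorophenyl in place of 3,5-difluorophenyl on an amide-type nitrogen. All three measured steps also change the group on that amide-type nitrogen: a 2.0-fold lower number from compound 1 to compound 2 (0.31 log units; beyond the scatter), a 7.1-fold lower number from compound 1 to compound 3 (0.85 log units; beyond the scatter) and a 3.5-fold lower number from compound 2 to compound 3 (0.54 log units; beyond the scatter), each a modest lowering. Compound 4, like compound 3, carries a halogen-bearing phenyl on the amide-type nitrogen, and the measured steps give no guidance between two such groups, so no step beyond the scatter is expected. The expected step of a 1.1-fold lower number from compound 3 to compound 4 (0.03 log units; within the scatter) is therefore small. The estimated value for compound 4 is 12000 nM, ranging from 4000 nM to 40000 nM.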

Compound 4, solubility: 9000 nM
Estimate against measurement, compound 4: 1.3-fold (0.12 log units) above, and the stated range covers the measured number.
By their numbers in this assay, from the lowest: compounds 4 and 3 (each within the scatter of the next); then compound 2; then compound 1.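

In this assay, 4-chlorophenyl in place of 3,5-difluorophenyl on the amide-type nitrogen gives a 1.4-fold lower number from compound 3 to compound 4 (0.16 log units; within the scatter), so these two halogen-bearing phenyl groups cannot be told apart here. Against the groups without halogen the change is clearer, with a 5.1-fold lower number from compound 2 to compound 4 (0.70 log units; beyond the scatter) and a 10-fold lower number from compound 1 to compound 4 (1.01 log units; beyond the scatter), the second being the only large step in the set. Nothing measured here explains these steps. Still open, on these data alone, is how a phenyl carrying an amine or a carboxylic acid would read at this position.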